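The source may hold more compounds than are shown below. What is called first, only, known or untested is meant among the compounds shown, and "the series" means these compounds.

Among the measured compounds shown here, in a functional assay on the whole organism with Scenedesmus acutus as the target (on this read-out lower numbers stand for stronger inhibition and higher numbers for weaker inhibition), compound 1 `CC(C)OC(=O)c1cc(N2C(=O)C3=C(CCCC3)C2=O)ccc1Cl` gives 1000 nM as the highest of the three numbers so far. Compound 2 `CC(C)OC(=O)c1cc(N2C(=O)C3=C(CCCC3)C2=O)c(F)cc1Cl` gives 57.5 nM and compound 3 `CCCCOC(=O)c1cc(N2C(=O)C3=C(CCCC3)C2=O)c(F)cc1Cl` gives 67.6 nM on the same read-out. Compound 4 `CCCCCOC(=O)c1cc(N2C(=O)C3=C(CCCC3)C2=O)ccc1Cl` differs from compound 1 in one place, with pentyl in place of isopropyl on an oxygen next to a carbonyl group as the change: pentyl in place of isopropyl on an oxygen next to a carbonyl group.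

The nearest measured change is butyl in place of isopropyl, a 1.2-fold higher number from compound 2 to compound 3 (0.07 log units; within the scatter) and so within the scatter. That step carries the fluoro that compound 1 and compound 4 lack, and a 17-fold lower number from compound 1 to compound 2 (1.24 log units; beyond the scatter) for fluoro in place of hydrogen shows how far that one place can move the number. No ester change has been measured without the fluoro, and no pentyl ester has been measured at all.

No step beyond the scatter is therefore expected in this assay for compound 4, though the range stays wide. The estimated change is a 1.1-fold lower number from compound 1 to compound 4 (0.05 log units; within the scatter) and nothing larger is assumed. Compound 4 is expected at 900 nM within an estimated range of 350 nM to 2200 nM for now.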

Compound 4, half-maximal inhibitory concentration: 9330 nM
Compound 4: the middle estimate sits 10-fold (1.02 log units) below what was measured; the whole stated range lies below it.
By their numbers in this assay, from the lowest: compounds 2 and 3 (each within the scatter of the next); then compound 1; then compound 4.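

In this assay, the ester oxygen turns out to be a place that can move the number: pentyl in place of isopropyl gives a 9.3-fold higher number from compound 1 to compound 4 (0.97 log units; beyond the scatter), whereas butyl in place of isopropyl on the fluoro compounds gave only a 1.2-fold higher number from compound 2 to compound 3 (0.07 log units; within the scatter). The earlier impression of a tolerant place therefore does not carry over to pentyl on the compound without fluoro, where the change goes towards weaker inhibition. Nothing on hand explains this step.

Going by these compounds, the two ester steps differ both in the entering chain and in the presence of fluoro, so it remains open whether pentyl would raise the number on the fluoro compound, or butyl on compound 1. Also open, on these data alone, is where a longer chain such as hexyl, or a free carboxylic acid, would fall at this place.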